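Swapping a thiophene for a chlorophenyl on the shared core

The source may report more compounds than this note shows. Statements on the series, on what has been measured and on what is new or still open speak of the compounds shown alone.

Measured compounds:
- compound 1, `c1ccc(-c2cn3ccnc3c(-c3ccc4ncn(C5CCCCC5)c4c3)n2)cc1`, 22.9%
- compound 2, `Fc1ccc(-c2cn3ccnc3c(-c3ccc4ncn(C5CCCCC5)c4c3)n2)cc1`, 14.2%
- compound 3, `c1cn2cc(-c3ccsc3)nc(-c3ccc4ncn(C5CCCCC5)c4c3)c2n1`, 0.39%

All three were tested in a functional assay on SNB-19 cells (Homo sapiens) for inhibition, read by sulforhodamine B assay, with a stated time of 48 h, tested at 10 uM; a lower number here means less inhibition, a higher number more inhibition at the concentration tested (going by the name of the read-out). Compound 3 stands lowest of the three numbers: compound 2 is nearest, a number 13.8 percentage points lower from compound 2 to compound 3 (beyond the scatter), and compound 1 is furthest, a number 22.5 percentage points lower from compound 1 to compound 3 (beyond the scatter). Between compound 1 and compound 2 the difference is small, a number 8.7 percentage points lower from compound 1 to compound 2 (within the scatter).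

Compound 4, `Clc1ccc(-c2cn3ccnc3c(-c3ccc4ncn(C5CCCCC5)c4c3)n2)cc1`, has not yet been measured in this assay. It differs from compound 3 in one place: 4-chlorophenyl in place of thiophen-3-yl on an aromatic carbon. Going by the values given here, two measured steps bear on this change. Both of them exchange a six-membered carbon ring for the thiophen-3-yl group: from compound 1 to compound 3, a number 22.5 percentage points lower from compound 1 to compound 3 (beyond the scatter), and from compound 2 to compound 3, a number 13.8 percentage points lower from compound 2 to compound 3 (beyond the scatter). The step to compound 4 runs the other way, restoring a six-membered carbon ring, and the closest measured comparison is compound 2, whose ring carries fluorine where compound 4 carries chlorine. Among the compounds with values here, no measured pair tells how chlorine and fluorine compare here.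

Compound 4 is therefore expected to sit above compound 3 by a modest amount, a number 14.6 percentage points higher from compound 3 to compound 4 (beyond the scatter), in this assay. The estimate for compound 4 is 15%, with a range from 4% to 30%.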

Compound 4, a percentage reported as inhibition, at one concentration (the size of the read-out at that concentration, not a potency): 15.8%
For compound 4 the middle estimate is 0.8 percentage points below the measured one; the range from low to high includes it.
By their numbers in this assay, from the lowest: compound 3; then compounds 2, 4 and 1 (each within the scatter of the next).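

In this assay, putting the 4-chlorophenyl group back in place of thiophen-3-yl gives a number 15.4 percentage points higher from compound 3 to compound 4 (beyond the scatter), so compound 1, compound 2 and compound 4, which all carry a six-membered aromatic ring of carbon only at this position, each stand beyond the scatter above compound 3, and no compound shown goes against this. Going by these compounds alone, what the earlier compounds could not show is how chlorine compares on that ring, and it makes no readable difference: chloro in place of fluoro gives a number 1.6 percentage points higher from compound 2 to compound 4 (within the scatter), and chloro in place of hydrogen gives a number 7.1 percentage points lower from compound 1 to compound 4 (within the scatter). Among these compounds, then, the readable change at this position comes from exchanging the ring itself, while hydrogen, fluoro and chloro on the six-membered ring cannot be told apart in this read-out.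

Nothing measured here gives a reason for the gap between the thiophen-3-yl compound and the other three. The compounds shown also leave open whether a different group on the six-membered ring, such as an amine or a carboxylic acid, or a pyridine ring in place of that ring, would move the number beyond the level of compound 1, compound 2 and compound 4.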